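The source may report more compounds than this note shows. Statements on the series, on what has been measured and on what is new or still open speak of the compounds shown alone.

In a functional assay on HT-29 cells (Homo sapiens) for antiproliferative activity, with a stated time of 48 h (on this read-out lower numbers stand for stronger inhibition and higher numbers for weaker inhibition), compound 1 `CCCCC(OC)c1cccc(NC(=O)NC(=O)CCl)c1` gives 10000 nM. Going by the values given here, compound 2 `CCCCCc1cccc(NC(=O)CCCCl)c1` differs from it in more than one place, so no single step links the two. In this assay compound 2 reaches only > 100000 nM, which is a boundary of the assay rather than a number, as described by the limit of > 100000 nM in this assay, at which 1 of the 2 values shown sits. Compound 3 `CCCCC(OC)c1cccc(NC(=O)CCCCl)c1` carries methoxy in place of hydrogen on a saturated chain carbon bound to an aromatic carbon and a saturated chain carbon. Among the compounds with values here, no measured step of this kind exists here, so the expected size of the move from compound 2 to compound 3 is estimated as a number no higher from compound 2 to compound 3 (the limit leaves the size open), with no clear direction beyond the scatter. Compound 3 is therefore expected at 100000 nM, between 30000 nM and 300000 nM.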

Compound 3, half-maximal inhibitory concentration: > 100000 nM
Compound 3: only a limit was reported; the forecaster's own chance of this, stated with the estimate: 60%; the middle value sits exactly at the limit.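

In this assay compound 3 stands at a limit of the assay, > 100000 nM, so the change from hydrogen to methoxy cannot be read, since both of its ends are limits. With methoxy present in both compounds, placing 3-chloropropyl where ((chloromethyl)carbonyl)amino stood on the carbonyl carbon gives an at least 10-fold higher number from compound 1 to compound 3 (1.00 log units; beyond the scatter). Most values shown now sit at one edge of the assay: the limit of > 100000 nM in this assay, at which 2 of the 3 values shown sit.

As far as these compounds go, whether methoxy at this saturated chain carbon matters at all remains open. So does what an amine or a longer chain at the same carbon would do.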